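This account rests on a few compounds, and the source may have more. Where it says the series, first, only, none or still open, it means among the compounds named here.

Working notes on the series. Compound 1 `COC(=O)C1=C(C)N=C(C)/C(=C(/O)OC)C1c1cccc(N/C(=N/CCNC2CCN(c3ccccc3C)CC2)NC#N)c1` gives 4 nM in an assay on SK-N-MC cells for inhibition of Neuropeptide Y receptor type 1 (Homo sapiens); on this read-out lower numbers stand for stronger inhibition and higher numbers for weaker inhibition. For the measured compounds named here, compound 2 `COC(=O)C1=C(C)N=C(C)/C(=C(/O)OC)C1c1cccc(N/C(=N/CCNC2CCN(c3ccccc3C#N)CC2)NC#N)c1` gives 3 nM in this assay, and the change a 1.3-fold lower number from compound 1 to compound 2 (0.12 log units; within the scatter) is the only single-point step among the measured compounds. Compound 3 `COC(=O)C1=C(C)N=C(C)/C(=C(/O)OC)C1c1cccc(NC(=O)NCCNC2CCN(c3ccccc3[N+](=O)[O-])CC2)c1` gives 2 nM in this assay, the lowest of the three numbers, though the gaps to compound 2 and to compound 1 both stay within the scatter, so no order among the three can be claimed.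

Compound 4 `COC(=O)C1=C(C)N=C(C)/C(=C(/O)OC)C1c1cccc(NC(=O)NCCNC2CCN(c3ccccc3OC(F)(F)F)CC2)c1` differs from compound 3 in one place: trifluoromethoxy in place of nitro on an aromatic carbon. Going by the values given here, the only measured step that bears on it is the exchange on the same aromatic carbon from compound 1 to compound 2, which was a 1.3-fold lower number from compound 1 to compound 2 (0.12 log units; within the scatter), within the scatter. Nothing measured suggests a change of group on this carbon moves the number beyond the scatter, so none is expected here either. Compound 4 is expected to give 3 nM in this assay, in a range from 1 nM to 10 nM. The expected step is a 1.5-fold higher number from compound 3 to compound 4 (0.18 log units; within the scatter), none beyond the scatter.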

Compound 4, half-maximal inhibitory concentration: 25 nM
Compound 4: the middle estimate sits 8.3-fold (0.92 log units) below what was measured, and the stated range ends below it.
By their numbers in this assay, from the lowest: compounds 3, 2 and 1 (each within the scatter of the next); then compound 4.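

In this assay, for the compounds shown here, the change from 2-nitrophenyl to 2-(trifluoromethoxy)phenyl gives a 13-fold higher number from compound 3 to compound 4 (1.10 log units; beyond the scatter), the first step beyond the scatter. This aromatic carbon, ortho to a large group, therefore does not accept every exchange without a change in the number, unlike the exchange giving a 1.3-fold lower number from compound 1 to compound 2 (0.12 log units; within the scatter), which stays within the scatter. That smaller step, however, belongs to a pair carrying a cyanoguanidine, whereas compound 3 and compound 4 carry a urea, so the two steps do not describe the same exchange in the same setting.

On these data alone, it remains open how a urea compound with methyl, nitrile, an amine or a carboxylic acid on this carbon would read, and whether trifluoromethoxy gives a step of similar size in the cyanoguanidine pair. Nothing available explains the size of the step from nitro to trifluoromethoxy.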